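Pentyl in place of 2-fluorophenyl: expected cytotoxicity of compound 4

The source may report more compounds than this note shows. Statements on the series, on what has been measured and on what is new or still open speak of the compounds shown alone.

The series shares one core: compound 1 `CCCCCCc1cn(C(c2ccccc2)c2cc3cc(Br)ccc3nc2OC)nn1` carries hexyl, compound 2 `CCCCc1cn(C(c2ccccc2)c2cc3cc(Br)ccc3nc2OC)nn1` butyl, compound 3 `COc1nc2ccc(Br)cc2cc1C(c1ccccc1)n1cc(-c2ccccc2F)nn1` 2-fluorophenyl. In an ADME assay on PC-3 cells (Homo sapiens) for cytotoxicity, read by sulforhodamine B assay, with a stated time of 48 h, tested at 10 uM (a lower number here means less inhibition, a higher number more inhibition at the concentration tested (going by the name of the read-out)), compound 1 gives 2.32%, compound 2 gives 5.54% and compound 3 gives 13.4%, the highest of the three numbers; the step of a number 11.1 percentage points higher from compound 1 to compound 3 (beyond the scatter) lies beyond the scatter, whereas a number 7.9 percentage points higher from compound 2 to compound 3 (within the scatter) and a number 3.2 percentage points higher from compound 1 to compound 2 (within the scatter) do not. Compound 4 `CCCCCc1cn(C(c2ccccc2)c2cc3cc(Br)ccc3nc2OC)nn1` differs from compound 3 by pentyl in place of 2-fluorophenyl on an aromatic carbon. The steps from the alkyl compounds to compound 3 bear on this change in reverse, so a decrease of roughly that size is expected, and since compound 1 and compound 2 sit within the scatter of each other, pentyl is expected to fall alongside them. Compound 4 is therefore expected to give 4%, within -4% to 12%. The expected step is a number 9.4 percentage points lower from compound 3 to compound 4 (within the scatter).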

Compound 4, a percentage reported as inhibition, at one concentration (the size of the read-out at that concentration, not a potency): 11.4%
Compound 4: middle estimate off by 7.4 percentage points, on the low side; measured number inside the range.
By their numbers in this assay, from the lowest: compounds 1, 2, 4 and 3 (each within the scatter of the next, the first and the last beyond it).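

In this assay, pentyl on the aromatic carbon of the five-membered aromatic ring stands level with 2-fluorophenyl, a number 2 percentage points lower from compound 3 to compound 4 (within the scatter), so alkyl and aryl groups do not separate cleanly at this position. Pentyl also stays level with its neighbours, a number 5.9 percentage points higher from compound 2 to compound 4 (within the scatter) and a number 9.1 percentage points higher from compound 1 to compound 4 (within the scatter), leaving only a number 11.1 percentage points higher from compound 1 to compound 3 (beyond the scatter) as a readable gap. Nothing available explains these numbers.

Open, going by these compounds, is whether an amine, a carboxylic acid or a chain longer than hexyl here would shift the number beyond the scatter. Also open, on these data alone, is what plain phenyl would give beside 2-fluorophenyl.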